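Enantiomer swap at the ring carbon of compound 1

A few compounds are considered here, and "the series" means these few. Any claim that something is new, unique, unknown or untested is made for them only; others in the source may bear on it.

Working notes on a small set of cyclic cyanoguanidines carrying an ester and an aryl group on the saturated ring. Compound 1 `CC1=C(C(=O)OC(C)C)[C@@H](c2ccco2)N/C(=N/C#N)N1` is the member with the furan-2-yl substituent drawn with S configuration. In an assay on HeLa cells for displacement of a labelled ligand from adenosine receptor A3 (Homo sapiens), with a stated time of 180 min, tested at 1 uM (a lower number here means less inhibition, a higher number more inhibition at the concentration tested (going by the name of the read-out)), compound 1 gives 4%, the lowest of the three numbers recorded. Compound 2 `CCOC(=O)C1=C(C)N/C(=N\C#N)NC1c1ccccc1`, the phenyl analogue with an ethyl ester and no drawn stereochemistry, gives 13% in this assay, which lies within the scatter of compound 1. Compound 3 `CC1=C(C(=O)OC(C)C)C(c2ccoc2)N/C(=N/C#N)N1`, the furan-3-yl analogue without drawn stereochemistry, gives 41% in this assay, beyond the scatter above compound 1.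

Compound 4 `CC1=C(C(=O)OC(C)C)[C@H](c2ccco2)N/C(=N/C#N)N1` is the mirror-image partner of compound 1 at the ring carbon: the two compounds have the same atoms and bonds and differ only in configuration as drawn: 1 of 2 stereo elements differ; a stereocentre at a saturated ring carbon is drawn S in compound 1 and R in compound 4. For the measured compounds named here, no step between two measured compounds isolates this kind of change, so its size cannot be read from the set. Since the other members were measured without a drawn configuration, their numbers could include a share from either form, and compound 1 sits at the bottom of the set with 4%. The change is expected to move this assay upward by a modest amount, a number 14 percentage points higher from compound 1 to compound 4 (beyond the scatter), possibly still within the scatter. Compound 4 is therefore estimated at 18% in this assay, within a range of 0% to 45%.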

Compound 4, a percentage reported as inhibition, at one concentration (the size of the read-out at that concentration, not a potency): 1%
Compound 4: the middle estimate sits 17 percentage points above what was measured; the measured number falls inside the stated range.
By their numbers in this assay, from the lowest: compounds 4, 1 and 2 (each within the scatter of the next, the first and the last beyond it); then compound 3.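

In this assay, for the compounds shown here, the first reading of this change gives a number 3 percentage points lower from compound 1 to compound 4 (within the scatter), so with the furan-2-yl group in place, drawing the stereocentre at the saturated ring carbon as S or R makes no readable difference at the concentration tested. The earlier compounds shown here could not show this, as only compound 1 had a drawn configuration and no partner to read it against. The step can be assigned to configuration alone and to no other part of the structure, because of this: the fact that compounds 1 and 4 differ only in the configuration as drawn.

Both members of the pair give small numbers from a single concentration, so the step says nothing about a potency difference that may exist at higher concentrations, and it holds for the furan-2-yl pair only. The compounds shown leave open whether the same stereocentre matters in the furan-3-yl compound 3, which gives 41% with no configuration drawn, and whether a carboxylic acid or an amide in place of the ester would change how little the configuration counts at this position.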